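The compounds below may be only part of what the source reports. "The series", "measured", "known", "first", "only" and "open" are said of these compounds alone.

In an ADME assay on HEK293 cells (Homo sapiens) for cytotoxicity, read by MTT assay, with a stated time of 48 h (on this read-out lower numbers stand for stronger inhibition and higher numbers for weaker inhibition), compound 1 (`N#Cc1nc2c(-c3nc4ccccc4[nH]3)c(N)n(CCN3CCCC3)c2nc1C#N`) gives 18300 nM and compound 2 (`CN(C)CCCn1c(N)c(-c2nc3ccccc3[nH]2)c2nc(C#N)c(C#N)nc21`) gives 8360 nM, the lower of the two numbers. The next compound to read is compound 3 (`CN1CCN(CCCn2c(N)c(-c3nc4ccccc4[nH]3)c3nc(C#N)c(C#N)nc32)CC1`). Its change from compound 2 is 4-methylpiperazin-1-yl in place of dimethylamino on a saturated chain carbon, three bonds along the chain from an aromatic nitrogen, on a saturated chain carbon, three bonds along the chain from an aromatic nitrogen. For the measured compounds named here, only one measured step bears on this: a 2.2-fold lower number from compound 1 to compound 2 (0.34 log units; beyond the scatter), a modest step that exchanged ring-bearing pyrrolidin-1-yl for open (dimethylamino)methyl. On that evidence, compound 3, which brings a ring back, is expected to move slightly toward higher numbers, probably without clearly leaving the scatter. Going by the values given here, no measured compound carries 4-methylpiperazin-1-yl, so the range stays wide. The expected size is a 1.4-fold higher number from compound 2 to compound 3 (0.16 log units; within the scatter). For compound 3 the estimated value is 12000 nM, with an expected range from 5000 nM to 28000 nM.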

Compound 3, half-maximal inhibitory concentration: 6260 nM
The estimate for compound 3 lay 1.9-fold (0.28 log units) above the measured number, within the range that was stated.
By their numbers in this assay, from the lowest: compounds 3 and 2 (each within the scatter of the next); then compound 1.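

In this assay, 4-methylpiperazin-1-yl in place of dimethylamino on a saturated chain carbon, three bonds along the chain from an aromatic nitrogen, stays within the scatter (a 1.3-fold lower number from compound 2 to compound 3 (0.13 log units; within the scatter)). This position therefore accepts the larger group, with its six-membered non-aromatic ring, without a readable change from the open dimethylamino group. A ring in the side chain does not by itself place a compound with compound 1, since compound 3 also carries one and the step between them lies beyond the scatter (a 2.9-fold lower number from compound 1 to compound 3 (0.47 log units; beyond the scatter)). No evidence is available to account for these readings.

Still open, going by these compounds, is how a morpholin-4-yl group or a primary amine would read at this position. On these data alone, the effect of a longer chain carrying the 4-methylpiperazin-1-yl group also remains open.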